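From 2-methylphenyl to hydrogen on a shared core

The source may report more compounds than this note shows. Statements on the series, on what has been measured and on what is new or still open speak of the compounds shown alone.

Compound 1 `Cc1ccccc1OCc1cn(-c2ccc(S(=O)(=O)N3CCc4ccccc4C3)cc2)nn1` has been tested in a functional assay on MOLT-3 cells (Homo sapiens) for cytotoxicity, read by MTT assay, with a stated time of 48 h; on this read-out higher numbers stand for weaker inhibition and lower numbers for stronger inhibition. In this assay compound 1 gives > 50 ug/mL, which is a limit and not a number. Compound 2 `COc1cc2c(cc1OC)CN(S(=O)(=O)c1ccc(-n3cc(COc4ccccc4C)nn3)cc1)CC2` gives > 50 ug/mL in this assay, which is also a limit. The starting point for this step is therefore a limit, with no exact value to compare against.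

Compound 3 `O=S(=O)(c1ccc(-n2cc(CO)nn2)cc1)N1CCc2ccccc2C1` keeps the core of compound 1 and changes one place: hydrogen in place of 2-methylphenyl on an oxygen on a saturated carbon. In words, hydrogen stands in place of 2-methylphenyl on an oxygen on a saturated carbon, so (2-methylphenoxy)methyl becomes hydroxymethyl. For the measured compounds named here, no measured pair shows what this change does in this assay. The data therefore set no direction, and no shift beyond the usual scatter is expected. This expectation rests on compound 1 and compound 2 sharing (the limit of > 50 ug/mL in this assay, at which 2 of the 2 values shown sit). The estimated change is a step that the limit leaves unreadable from compound 1 to compound 3. For compound 3 the estimated value is 55 ug/mL. The expected range for compound 3 runs from 20 ug/mL to 100 ug/mL.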

Compound 3, half-maximal inhibitory concentration: > 50 ug/mL
Compound 3 was reported as a limit (the forecaster's own chance of this, stated with the estimate: 65%); the middle value is on the limit's open side.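

Compound 1 and compound 3 are both reported only as limits in this assay, so the step from one to the other cannot be read: the limit of > 50 ug/mL in this assay, at which 3 of the 3 values shown sit.

With no exact number among them, the compounds shown leave open what putting hydrogen in place of 2-methylphenyl does in this assay, and which changes to the shared core would give a readable value.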